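Second Chloro Added Where Both Parents Show Only Limits

A few compounds are considered here, and "the series" means these few. Any claim that something is new, unique, unknown or untested is made for them only; others in the source may bear on it.

Compound 1, `Cn1c(SCc2ccccc2)nnc1-c1cc([N+](=O)[O-])cc([N+](=O)[O-])c1`, gives a limit of > 30000 nM.
Compound 2, `Cn1c(SCc2ccc(Cl)cc2)nnc1-c1cc([N+](=O)[O-])cc([N+](=O)[O-])c1`, gives a limit of > 30000 nM.

In an ADME assay on A-431 cells (Homo sapiens) for cytotoxicity, with a stated time of 48 h (a higher number here means a weaker inhibitor, a lower number a stronger inhibitor), compound 2 reaches only the limit of the assay, > 30000 nM. The step that the two limits leave unreadable from compound 1 to compound 2 therefore cannot be read. Compound 3, `Cn1c(SCc2ccc(Cl)c(Cl)c2)nnc1-c1cc([N+](=O)[O-])cc([N+](=O)[O-])c1`, differs from compound 2 by chloro in place of hydrogen on an aromatic carbon. Among the measured compounds shown here, no measured step bears on this change, because the limit of > 30000 nM in this assay, at which 2 of the 2 values shown sit, leaves no readable size in either direction. Compound 3 is expected to sit at the limit as well, with an estimate of 45000 nM, between 15000 nM and 150000 nM. This expected step is a step that the limit leaves unreadable from compound 2 to compound 3.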

Compound 3, half-maximal inhibitory concentration: > 30000 nM
Compound 3: a limit, no number (the forecaster's own chance of this, stated with the estimate: 85%); the middle value is on the limit's open side.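

No step between compound 1, compound 2 and compound 3 can be read, because all three stop at the same limit rather than a number: the limit of > 30000 nM in this assay, at which 3 of the 3 values shown sit.

Going by these compounds, whether either added chloro changes the strength of inhibition at all stays open.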